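Adding a Propylcarbonyl Group to a Squalene Synthase Inhibitor

The source may report more compounds than this note shows. Statements on the series, on what has been measured and on what is new or still open speak of the compounds shown alone.

Measured compounds:
compound 1 `C=CCc1cc(C(=O)CCC)ccc1OCC(O)CNC(C)C`: 4.5 nM
compound 2 `C=CCc1ccccc1OCCCNC(C)C`: 56 nM

Both were tested in an assay for inhibition of squalene synthase (Rattus norvegicus), using microsomes; a higher number here means a weaker inhibitor, a lower number a stronger inhibitor. Compound 2 has the higher of the two numbers; compound 1 sits well below it, and that gap lies beyond the scatter, so compound 2 is the weaker inhibitor of the pair. Compound 1 differs from compound 2 in more than one place, so the two numbers alone do not show how much of the gap belongs to any single change.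

Compound 3 `C=CCc1cc(C(=O)CCC)ccc1OCCCNC(C)C` takes one of those changes on its own: propylcarbonyl in place of hydrogen on an aromatic carbon. No direct comparison of this change is available, so the expected size of the step must be read from the two numbers in hand. Since compound 1, which also carries the propylcarbonyl group, gives 4.5 nM, the step is expected to lower the number, likely beyond the scatter. Compound 3 is therefore expected to give about 12 nM, with a plausible range from 3 nM to 45 nM. That expectation corresponds to a step of a 4.7-fold lower number from compound 2 to compound 3 (0.67 log units; beyond the scatter) in this assay.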

Compound 3, half-maximal inhibitory concentration: 1 nM
The estimate for compound 3 lay 12-fold (1.08 log units) above the measured number; measured number outside the range, below it.
By their numbers in this assay, from the lowest: compound 3; then compound 1; then compound 2.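

Taken on its own, propylcarbonyl in place of hydrogen on this aromatic carbon gives a 56-fold lower number from compound 2 to compound 3 (1.75 log units; beyond the scatter) in this assay, so this single change is enough for a large drop in the number. The second comparison concerns the chain rather than the aromatic carbon: hydrogen in place of hydroxy on a saturated chain carbon gives a 4.5-fold lower number from compound 1 to compound 3 (0.65 log units; beyond the scatter), a modest step, yet one beyond the scatter. The hydroxy group of compound 1 is therefore not needed for strong inhibition here, and removing it leaves compound 3 as the strongest inhibitor of the three, although this reading holds only with propylcarbonyl present.

Still open, from the compounds shown here alone, is whether a longer chain on the carbonyl, such as butylcarbonyl, or a smaller one, such as acetyl, would lower the number further, and how large the hydroxy step would be on a compound without propylcarbonyl. Nothing available here accounts for why either change moves the number as it does.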